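Amide aryl swap at the carbonyl of compound 1

This account rests on a few compounds, and the source may have more. Where it says the series, first, only, none or still open, it means among the compounds named here.

Measured in a functional assay on SK-BR-3 cells (Homo sapiens) for antiproliferative activity, read by MTT assay, with a stated time of 72 h; a lower number here means a stronger inhibitor, a higher number a weaker inhibitor:
compound 1 `CCN1CCN(c2cc(C)c3cc(NC(=O)c4ccc(C)cc4)ccc3n2)CC1` gives 11400 nM
compound 2 `Cc1cc(NCCN2CCCC2)nc2ccc(NC(=O)c3ccc(Cl)c(Cl)c3)cc12` gives 9530 nM
compound 3 `Cc1cc(N2CCCCC2)nc2ccc(NC(=O)c3ccc(Cl)c(Cl)c3)cc12` gives 42500 nM

Compound 1 stands second highest of the three numbers; its value and that of compound 2 lie within the scatter of each other, while compound 3 sits higher, beyond the scatter. Compound 4 `CCN1CCN(c2cc(C)c3cc(NC(=O)c4ccccc4Cl)ccc3n2)CC1` differs from compound 1 as follows: 2-chlorophenyl in place of 4-methylphenyl on a carbonyl carbon. Among the measured compounds shown here, the only measured step, a 4.5-fold higher number from compound 2 to compound 3 (0.65 log units; beyond the scatter), concerns the group on an aromatic carbon of the shared core, not the carbonyl, so no measured step bears on this change and it is read as neutral. The expected step is therefore a 1.0-fold lower number from compound 1 to compound 4 (0.02 log units; within the scatter), none beyond the scatter. Compound 4 is estimated at 11000 nM, ranging from 4000 nM to 35000 nM in this assay.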

Compound 4, half-maximal inhibitory concentration: > 50000 nM
Compound 4 gave a limit, no number; the forecaster's own chance of this, stated with the estimate: 10%; middle value at least 4.5-fold (0.65 log units) from the limit.
By their numbers in this assay, from the lowest: compounds 2 and 1 (each within the scatter of the next); then compound 3. At a limit, above all of these: compound 4.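

The aryl group on the carbonyl carbon now has a measured step of its own in this assay: 2-chlorophenyl in place of 4-methylphenyl gives an at least 4.3-fold higher number from compound 1 to compound 4 (0.64 log units; beyond the scatter). This position is therefore not neutral to the aryl group, even with the rest of compound 1 unchanged. Compound 4 gives > 50000 nM, which is a limit of the assay and not a number: the limit of > 50000 nM in this assay, at which 1 of the 4 values shown sits.

On these data alone, how far compound 4 lies past that limit remains open. Also open, as far as these compounds go, is whether 4-chlorophenyl or 2-methylphenyl on the same carbonyl carbon would read closer to compound 1 or to compound 4, which would separate the chlorine from its ring position.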